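The source may hold more compounds than are shown below. What is called first, only, known or untested is meant among the compounds shown, and "the series" means these compounds.

Measured in a functional assay on K562 cells (Homo sapiens) for antiproliferative activity, read by MTT assay, with a stated time of 24 h; a higher number here means a weaker inhibitor, a lower number a stronger inhibitor:
- Compound 1 `COc1ccc(C(=O)/C=C/c2ccc(F)cc2)c2c1C=CC(C)(C)O2`: > 10000 nM, a limit
- Compound 2 `COc1ccc(C(=O)/C=C/c2ccc(-c3ccccc3)cc2)c2c1C=CC(C)(C)O2`: > 10000 nM, a limit

Among the compounds with values here, neither entry is a number, so the series so far offers no measured potency to build on. Within the data shown here, compound 2 stands only at a limit, > 10000 nM, and the same is true of the only other compound, as the limit of > 10000 nM in this assay, at which 2 of the 2 values shown sit, shows. The next compound is compound 3 `CCN(CC)c1ccc(/C=C/C(=O)c2ccc(OC)c3c2OC(C)(C)C=C3)cc1`, with diethylamino in place of phenyl on an aromatic carbon, para to a large group: diethylamino in place of phenyl on an aromatic carbon. Among the measured compounds shown here, one measured step bears on this change, since it also replaces a group on an aromatic carbon: a step that the two limits leave unreadable from compound 1 to compound 2. Its size cannot be read, so it gives no size to carry over. Nothing measured points to a clear change in this assay, and compound 3 is expected most probably to stay at the limit. A readable step would arise only if compound 3 gave a number on the stronger side of it. The expected change is a step that the limit leaves unreadable from compound 2 to compound 3. For compound 3 the estimated value is 14000 nM, with an expected range from 5000 nM to 40000 nM.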

Compound 3, half-maximal inhibitory concentration: 790 nM
Compound 3: middle estimate off by 18-fold (1.25 log units), on the high side, outside the stated range (below it).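

At the aromatic carbon para to a large group, the choice of substituent now makes a readable difference in this assay: diethylamino in place of phenyl gives an at least 12-fold lower number from compound 2 to compound 3 (1.10 log units; beyond the scatter), and diethylamino in place of fluoro gives an at least 12-fold lower number from compound 1 to compound 3 (1.10 log units; beyond the scatter). The earlier step between compound 1 and compound 2 cannot be read, so these two steps are the only sizes available at this position, and each gives only a minimum, as the other end of each is a limit and not a number. Compound 3 alone carries a measured number in this small set, while the other two remain at the limit: the limit of > 10000 nM in this assay, at which 2 of the 3 values shown sit.

The compounds shown leave open whether the step belongs to the nitrogen attached to the aromatic ring or to the two ethyl groups on it, and how a dimethylamino group, a morpholine or a primary amine would compare at the same carbon. They also leave open how far the number would move with an alkoxy group such as methoxy there, and whether any change to the shared core would alter the step.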